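Benzyl for tert-butyl on the oxime oxygen of a uridine triphosphate

The source may report more compounds than this note shows. Statements on the series, on what has been measured and on what is new or still open speak of the compounds shown alone.

Compound 1 `O=c1[nH]/c(=N\OCc2ccccc2)ccn1[C@@H]1O[C@H](COP(=O)(O)OP(=O)(O)OP(=O)(O)OP(=O)(O)O[C@H]2O[C@H](CO)[C@@H](O)[C@H](F)[C@H]2O)[C@@H](O)[C@H]1O`: 670 nM
Compound 2 `CO/N=c1/ccn([C@@H]2O[C@H](COP(=O)(O)OP(=O)(O)OP(=O)(O)OP(=O)(O)O[C@H]3O[C@H](CO)[C@@H](O)[C@H](F)[C@H]3O)[C@@H](O)[C@H]2O)c(=O)[nH]1`: 310 nM
Compound 3 `CC(C)(C)O/N=c1/ccn([C@@H]2O[C@H](COP(=O)(O)OP(=O)(O)OP(=O)(O)O)[C@@H](O)[C@H]2O)c(=O)[nH]1`: 2110 nM

In an in vitro functional assay on 1321-N1 cells for agonist activity at P2Y purinoceptor 4 (Homo sapiens), read by scintillation proximity assay and inositol phosphate accumulation, with a stated time of 30 min (on this read-out higher numbers stand for an effect only at larger amounts of compound and lower numbers for an effect already at smaller amounts), compound 3 gives the highest of the three numbers: compound 1 sits at a lower number, and compound 2 at a lower number still. Compound 4 `O=c1[nH]/c(=N\OCc2ccccc2)ccn1[C@@H]1O[C@H](COP(=O)(O)OP(=O)(O)OP(=O)(O)O)[C@@H](O)[C@H]1O` differs from compound 3 in one place, (benzyl in place of tert-butyl on an oxygen). Going by the values given here, no measured pair reproduces exactly this change. Among the compounds with values here, the one measured step in this assay, a 2.2-fold lower number from compound 1 to compound 2 (0.33 log units; beyond the scatter), concerns a different substituent on that same oxygen and is made in a different series, so it bears only loosely on the present move. Taken with the standing of compound 3 above both other compounds, the pattern suggests that the smaller groups on this oxygen go with lower numbers, while benzyl lies somewhere between tert-butyl and methyl. A modest step toward a lower number is therefore expected for compound 4, a 2.1-fold lower number from compound 3 to compound 4 (0.32 log units; beyond the scatter). The estimate for compound 4 in this assay is 1000 nM, within the range 350 nM to 3000 nM.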

Compound 4, half-maximal effective concentration: 97 nM
The estimate for compound 4 lay 10-fold (1.01 log units) above the measured number; measured number outside the range, below it.
By their numbers in this assay, from the lowest: compound 4; then compound 2; then compound 1; then compound 3.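

Changing tert-butyl to benzyl on the oxygen whose other neighbour is the double-bonded nitrogen produces a large effect in this assay, with a 22-fold lower number from compound 3 to compound 4 (1.34 log units; beyond the scatter). This exceeds the modest 2.2-fold lower number from compound 1 to compound 2 (0.33 log units; beyond the scatter), so this oxygen tolerates substituent changes with much larger consequences than that earlier step showed. Size alone gives no single trend across the two series: the seven-carbon benzyl beats the four-carbon tert-butyl in compound 4, whereas compound 2 goes against this, with methyl giving a lower number than the benzyl of compound 1, and nothing available explains the size of the new step.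

The compounds shown leave open whether the aromatic ring itself or merely the carbon chain joining it to the oxygen accounts for the step. They also leave open how a longer chain such as phenylethyl, or a benzyl ring carrying an amine or a carboxylic acid, would read here.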